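Working notes: from compound 2 to compound 3

The source may hold more compounds than are shown below. What is called first, only, known or untested is meant among the compounds shown, and "the series" means these compounds.

Values in a functional assay on CCRF-CEM cells (Homo sapiens) for cytotoxicity, in the absence of a further agent (a lower number here means a stronger inhibitor, a higher number a weaker inhibitor), so far
- compound 1 `COC(=O)c1ccc(CN(CCCc2c(N)nc(N)nc2O)c2cc(F)cc(F)c2[N+](=O)[O-])cc1` gives > 100000 nM as a limit
- compound 2 `Nc1nc(N)c(CCCN(Cc2ccc(NC(CCC(=O)O)C(=O)O)cc2)c2cc(F)ccc2[N+](=O)[O-])c(O)n1` gives > 100000 nM as a limit

Compound 2 has no number, only a limit, and both measured compounds share the limit of > 100000 nM in this assay, at which 2 of the 2 values shown sit, as their reading. Going to compound 3 `COC(=O)c1ccc(CN(CCCc2c(N)nc(N)nc2O)c2cc(F)ccc2[N+](=O)[O-])cc1` puts methoxycarbonyl in place of (1,3-dicarboxypropyl)amino on an aromatic carbon as the whole change. Among the compounds with values here, no measured step in this assay sizes this change. Compound 2 at > 100000 nM is a limit and the only anchor. The step of an at least 1.2-fold lower number from compound 2 to compound 3 (0.09 log units; that floor lies within the scatter) is expected to be small, if anything towards stronger inhibition, and another limit reading is likely. Compound 3 is estimated at 80000 nM with an expected range of 20000 nM to 200000 nM in these notes.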

Compound 3, half-maximal inhibitory concentration: 43000 nM
The estimate for compound 3 lay 1.9-fold (0.27 log units) above the measured number; the measured number falls inside the stated range.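

In this assay, within the data shown here, compound 3 gives the first reading that is a number and not a limit. Methoxycarbonyl in place of (1,3-dicarboxypropyl)amino on an aromatic carbon gives an at least 2.3-fold lower number from compound 2 to compound 3 (0.36 log units; beyond the scatter), and hydrogen in place of fluoro on an aromatic carbon gives an at least 2.3-fold lower number from compound 1 to compound 3 (0.36 log units; beyond the scatter). Both steps start from a limit, so their full size stays unknown: the limit of > 100000 nM in this assay, at which 2 of the 3 values shown sit.

Open, on these data alone, is how a carboxylic acid or a primary amide in place of methoxycarbonyl on this aromatic carbon would read against compound 3. Also open, as far as these compounds go, is whether a longer chain in the shared core would move the number.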